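A few compounds are considered here, and "the series" means these few. Any claim that something is new, unique, unknown or untested is made for them only; others in the source may bear on it.

Measured so far:
Compound 1 `C=CCSS/C=C\C[S+]([O-])CCC`: 17000 nM
Compound 2 `C=CCSS/C=C/C[S+]([O-])CCCO`: 23100 nM

Both compounds were tested in a functional assay on cells (Fibroblast) for antiproliferative activity; a lower number here means a stronger inhibitor, a higher number a weaker inhibitor. There, compound 2 at 23100 nM stands within the usual scatter of compound 1 at 17000 nM.

Compound 3 `C=CCSS/C=C\C[S+]([O-])CCCO` has not yet been measured in this assay. It has the same atoms and bonds as compound 2, and the two differ in one stereo element: the two compounds have the same atoms and bonds; at least one stereo element is drawn with a configuration in one of them and without one in the other: 1 of 2 stereo elements differ; a double bond is drawn E in compound 2 and Z in compound 3. A double bond is drawn E in compound 2 and Z in compound 3. Within the data shown here, no pair of measured compounds isolates this change, so the data give no direct measure of it. No step beyond the scatter is therefore expected, in either direction. The estimated step is a 1.1-fold lower number from compound 2 to compound 3 (0.04 log units; within the scatter). For compound 3 the expected value is 21000 nM, with an estimated range of 11000 nM to 40000 nM.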

Compound 3, half-maximal inhibitory concentration: 22800 nM
Estimate against measurement, compound 3: 1.1-fold (0.04 log units) below, within the range that was stated.
By their numbers in this assay, from the lowest: compounds 1, 3 and 2 (each within the scatter of the next).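

In this assay, changing the double bond from E to Z leaves the number within the scatter: the result is a 1.0-fold lower number from compound 2 to compound 3 (0.01 log units; within the scatter). Among these compounds, this is the first direct reading of that double bond, and it also gives the first reading of the chain end, where hydroxy in place of hydrogen on a saturated chain carbon, three bonds along the chain from a sulfur, gives a 1.3-fold higher number from compound 1 to compound 3 (0.13 log units; within the scatter). One caution applies to how the double-bond comparison is read: the fact that one of compounds 2 and 3 is drawn with a defined configuration and the other without, at the place where they differ

The compounds shown leave open whether an amine or a carboxylic acid in place of the hydroxy would move the number beyond the scatter. They also leave open whether a longer chain at this position would do so.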